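This account rests on a few compounds, and the source may have more. Where it says the series, first, only, none or still open, it means among the compounds named here.

Compound 1 `Cc1ccc(Nc2nc(Cl)nc3c2ncn3Cc2ccc(C(=O)Nc3ccccc3N)cc2)cc1`: in a functional assay on HepG2 cells (Homo sapiens) for antiproliferative activity, read by CCK-8 assay, with a stated time of 72 h, tested at 8 uM (a lower number here means a weaker effect, a higher number a stronger effect of the compound at the concentration tested), compound 1 gives 82%. Compound 2 `Nc1ccccc1NC(=O)c1ccc(Cn2cnc3c(Nc4ccccc4)nc(Cl)nc32)cc1`: in this assay compound 2 gives 74.8%.

Compound 1 has the higher of the two numbers, but the step of a number 7.2 percentage points lower from compound 1 to compound 2 (within the scatter) lies within the scatter, so the two compounds cannot be told apart. Compound 3 `Cc1ccc(Nc2nc(Cl)nc3c2ncn3Cc2ccc(/C=C/C(=O)Nc3ccccc3N)cc2)cc1` differs from compound 1 in one place: 2-((2-aminophenyl)carbamoyl)ethenyl in place of (2-aminophenyl)carbamoyl on an aromatic carbon. Among the measured compounds shown here, no measured step touches this part of the molecule, so nothing here predicts a shift in this assay; the only measured step, the one from compound 1 to compound 2, was small and elsewhere. For compound 3 the expected step of a number 2 percentage points lower from compound 1 to compound 3 (within the scatter) is none beyond the scatter, with an estimate of 80% and a range from 62% to 94%.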

Compound 3, a percentage reported as inhibition, at one concentration (the size of the read-out at that concentration, not a potency): 43%
Compound 3: middle estimate off by 37 percentage points, on the high side; the measured number lies below the stated range.
By their numbers in this assay, from the lowest: compound 3; then compounds 2 and 1 (each within the scatter of the next).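

Among the compounds shown here, this position tolerates little change: in this assay, inserting the ethenyl link, so that 2-((2-aminophenyl)carbamoyl)ethenyl replaces (2-aminophenyl)carbamoyl on the aromatic carbon, gives a number 39 percentage points lower from compound 1 to compound 3 (beyond the scatter) while the only earlier step, made elsewhere on the molecule, stayed within the scatter. Nothing available explains why this change lowers the number. As far as these compounds go, it remains open whether an ethylene chain, the saturated counterpart of the ethenyl link, would give a similar drop. Also open, from the compounds shown here alone, is how a hydroxamic acid in place of the 2-aminophenyl amide would read out at this position.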